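A few compounds are considered here, and "the series" means these few. Any claim that something is new, unique, unknown or untested is made for them only; others in the source may bear on it.

Series notes. The shared core is an amide bearing a varying aryl group: compound 1 `CCOC(=O)CCCCCOc1cccc(CN(C(=O)c2ccc(-c3cccc(N(C)C)c3)cc2)C(C)C)c1` carries 3-(dimethylamino)phenyl, compound 2 `CCOC(=O)CCCCCOc1cccc(CN(C(=O)c2ccc(-c3cnc(OC)nc3OC)cc2)C(C)C)c1` carries 2,4-dimethoxypyrimidin-5-yl, and compound 3 `CCOC(=O)CCCCCOc1cccc(CN(C(=O)c2ccc(-c3cccc(OC(C)C)c3)cc2)C(C)C)c1` carries 3-isopropoxyphenyl. Cytotoxicity is read in an ADME assay on Raji cells (Homo sapiens) for cytotoxicity, read by CellTiter-Glo and resazurin assay, with a stated time of 72 h; on this read-out lower numbers stand for an effect already at smaller amounts and higher numbers for an effect only at larger amounts of compound. In this assay compound 1 reaches only the limit > 26000 nM. In this assay compound 2 likewise reaches only the limit > 26000 nM. In this assay compound 3 also reaches only the limit > 26000 nM. Compound 3 thus stands together with the other two at one limit, (the limit of > 26000 nM in this assay, at which 3 of the 3 values shown sit), and each step among the three is left unreadable by the limits, whether a step that the two limits leave unreadable from compound 1 to compound 2, a step that the two limits leave unreadable from compound 1 to compound 3 or a step that the two limits leave unreadable from compound 2 to compound 3. The next step goes to compound 4 `CCOC(=O)CCCCCOc1cccc(CN(C(=O)c2ccc(-c3cccc(-c4nnc(C)o4)c3)cc2)C(C)C)c1`, which differs from compound 3 by 5-methyl-1,3,4-oxadiazol-2-yl in place of isopropoxy on an aromatic carbon. For the measured compounds named here, the steps that bear on it, a step that the two limits leave unreadable from compound 1 to compound 3 and a step that the two limits leave unreadable from compound 2 to compound 3, both involve the isopropoxy group but give no size. With no readable step and every value at the limit, no step beyond the scatter is expected in this assay, so the estimated step is a step that the limit leaves unreadable from compound 3 to compound 4. Compound 4 is therefore estimated to give 30000 nM in this assay, with a range from 15000 nM to 60000 nM, most likely again reported only as a limit.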

Compound 4, half-maximal effective concentration: > 26000 nM
Compound 4 was reported as a limit; the forecaster's own chance of this, stated with the estimate: 85%; the middle value does not contradict the limit.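

Compound 4 gives > 26000 nM in this assay, which is a limit, so no new step can be read between compound 4 and compound 1, compound 2 or compound 3; all four stand at one limit: the limit of > 26000 nM in this assay, at which 4 of the 4 values shown sit.

The compounds shown leave open whether any aryl change on the shared core produces a readable cytotoxic effect in this assay.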